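Amide substituent change from compound 3 to compound 4

The compounds below may be only part of what the source reports. "The series", "measured", "known", "first", "only" and "open" are said of these compounds alone.

Within the data shown here, in an ADME assay on MT4 cells (Homo sapiens) for cytotoxicity, read by MTT assay (on this read-out lower numbers stand for higher toxicity in this test and higher numbers for lower toxicity in this test), compound 3 (`Cc1cc(C)cc(S(=O)(=O)c2c(C(=O)NC(C)C(=O)NC(C)c3ccccc3F)[nH]c3ccc(Cl)cc23)c1`) gives 15200 nM, the only value so far that is a number. Compound 1 (`Cc1cc(C)cc(S(=O)(=O)c2c(C(=O)NCC(=O)NCc3ccco3)[nH]c3ccc(Cl)cc23)c1`) gives > 50000 nM, which is a limit of the assay. Compound 2 (`Cc1cc(C)cc(S(=O)(=O)c2c(C(=O)NC(c3ccc(Cl)cc3)C3CC3)[nH]c3ccc(Cl)cc23)c1`) gives > 47300 nM, which is also a limit of the assay.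

Compound 4 (`Cc1cc(C)cc(S(=O)(=O)c2c(C(=O)NC(C)C(=O)NCc3ccncn3)[nH]c3ccc(Cl)cc23)c1`) has not yet been measured. The change leading to it is (pyrimidin-4-yl)methyl in place of 1-(2-fluorophenyl)ethyl on an amide-type nitrogen. Among the measured compounds shown here, the one measured step at this kind of place, a step that the two limits leave unreadable from compound 1 to compound 2, also exchanges the group on an amide-type nitrogen, but it has no readable size and sets no scale.

The direction rests weakly on compound 1, whose > 50000 nM is a limit and whose group holds an aromatic ring with 1 hetero atom. Compound 2 goes against that reading: its > 47300 nM is likewise a limit, with carbon-only rings in its group. A modest move towards higher numbers in this assay is therefore expected, as a 2.6-fold higher number from compound 3 to compound 4 (0.42 log units; beyond the scatter), and the assay may report only a limit. For compound 4 the estimated value is 40000 nM, with an expected range of 15000 nM to 100000 nM.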

Compound 4, half-maximal cytotoxic concentration: 28100 nM
Estimate against measurement, compound 4: 1.4-fold (0.15 log units) above; the measured number falls inside the stated range.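

In this assay, among these compounds, (pyrimidin-4-yl)methyl in place of 1-(2-fluorophenyl)ethyl on an amide-type nitrogen gives the first step of readable size at this kind of place: a 1.8-fold higher number from compound 3 to compound 4 (0.27 log units; within the scatter), so compound 3 and compound 4 cannot be told apart, and the aromatic ring of (pyrimidin-4-yl)methyl serves here as well as a carbon-only aromatic ring carrying fluorine, as far as this read-out goes. The comparisons with the two compounds that stand at limits of the assay give only floors, an at least 1.6-fold lower number from compound 2 to compound 4 (0.22 log units; that floor lies within the scatter) and an at least 1.7-fold lower number from compound 1 to compound 4 (0.25 log units; that floor lies within the scatter), and as both floors lie within the scatter, neither separates compound 4 from compound 1 or compound 2. The values shown carry no information on why these numbers sit where they do.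

The exchange alters the ring and the carbon chain on the amide-type nitrogen at once, so 1-(pyrimidin-4-yl)ethyl or 2-fluorobenzyl would be needed to take the two parts apart. How far the read-out moves at this place with an amine or a carboxylic acid on the group remains open, since the groups shown so far all end in an aromatic ring.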